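Swapping Methoxy for Chloro in a Small Solubility Series

A few compounds are considered here, and "the series" means these few. Any claim that something is new, unique, unknown or untested is made for them only; others in the source may bear on it.

Compound 1 `CCOC(=O)c1c(-c2ccccc2)[nH]c2cc(OC)ccc2c1=O`: > 100000 nM (a limit, not a number)
Compound 2 `CCOC(=O)c1c(-c2ccc(C(F)(F)F)cc2)[nH]c2cc(OC)ccc2c1=O`: 8000 nM
Compound 3 `CCOC(=O)c1c(-c2ccc(OC)cc2)[nH]c2cc(OC)ccc2c1=O`: 8000 nM

In a physicochemical assay for solubility, in phosphate buffer, at pH 7.4 (on this read-out higher numbers stand for higher solubility and lower numbers for lower solubility), compound 3 gives 8000 nM, the same figure as compound 2 at the digits shown. Compound 4 `CCOC(=O)c1c(-c2ccc(Cl)cc2)[nH]c2cc(OC)ccc2c1=O` has not yet been measured. It carries chloro in place of methoxy on an aromatic carbon of a six-membered aromatic ring of carbon only, para to a large group: chloro in place of methoxy on an aromatic carbon.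

Two measured steps put a group in place of hydrogen on an aromatic carbon: an at least 12-fold lower number from compound 1 to compound 2 (1.09 log units; beyond the scatter) and an at least 12-fold lower number from compound 1 to compound 3 (1.09 log units; beyond the scatter). Both are large and both start from the limit, but neither exchanges one group for another, so they bear on the present change only loosely. The closest guide is no change at the digits printed from compound 2 to compound 3 (within the scatter), with methoxy in place of trifluoromethyl, and it lies within the scatter. On that single exchange, no step beyond the scatter is expected in this assay, in either direction.

The estimated step is a 1.1-fold lower number from compound 3 to compound 4 (0.06 log units; within the scatter). For compound 4 the estimated value is 7000 nM, with an expected range from 2500 nM to 20000 nM.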

Compound 4, solubility: 3000 nM
For compound 4 the middle estimate is 2.3-fold (0.37 log units) above the measured one, and the stated range covers the measured number.
By their numbers in this assay, from the lowest: compound 4; then compounds 2 and 3 (each within the scatter of the next). At a limit, above all of these: compound 1.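

In this assay, the exchange of one group for another at this place on the aromatic ring now separates two compounds, which the earlier exchange had not done: a 2.7-fold lower number from compound 3 to compound 4 (0.43 log units; beyond the scatter) and a 2.7-fold lower number from compound 2 to compound 4 (0.43 log units; beyond the scatter), each beyond the scatter. Chloro therefore stands apart from both methoxy and trifluoromethyl, two groups that print the same figure here, and the one earlier exchange did not show that such a swap could move the number at all. Put in place of hydrogen, chloro gives an at least 33-fold lower number from compound 1 to compound 4 (1.52 log units; beyond the scatter), but that step starts from compound 1, which gives a limit and not a number: the limit of > 100000 nM in this assay, at which 1 of the 4 values shown sits.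

Only chloro, methoxy, trifluoromethyl and hydrogen are shown at this place, so it remains open whether an amine, a carboxylic acid or a longer chain there would sit with compound 4 or with compounds 2 and 3. The compounds shown also offer no measured property that accounts for chloro standing apart, and they leave open whether the same gap would hold with a change elsewhere on the shared core.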